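Fluoro in Place of Methyl on the Benzyl Ring

The source may hold more compounds than are shown below. What is called first, only, known or untested is meant among the compounds shown, and "the series" means these compounds.

Of the compounds shown here, three sharing one core have been tested in an assay on isolated protein for inhibition of aldehyde dehydrogenase 1A1 (Homo sapiens), read by spectrophotometry, tested at 10 uM; on this read-out lower numbers stand for less inhibition and higher numbers for more inhibition at the one concentration tested (going by the name of the read-out). Compound 1 `CCC(=O)N1CCN(Cc2nc3ccccc3n2Cc2cccc(C)c2)CC1` gives 85.1%. Compound 2 `Cc1ccccc1Cn1c(CN2CCN(C(=O)C3CC3)CC2)nc2ccccc21` gives 29.1%, and compound 3 `Cc1cccc(Cn2c(CN3CCN(C(=O)c4ccc(C(F)(F)F)cc4)CC3)nc3ccccc32)c1` gives 22.9%. Among these three numbers compound 2 stands second highest; compound 3 is nearest to it and the two values lie within the scatter of each other, while compound 1 stands furthest from it, beyond the scatter. Among the compounds with values here, the one measured step between compounds that differ in a single place runs from compound 1 to compound 3: a number 62.2 percentage points lower from compound 1 to compound 3 (beyond the scatter), with 4-(trifluoromethyl)phenyl in place of ethyl on a carbonyl carbon.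

Compound 4 `O=C(C1CC1)N1CCN(Cc2nc3ccccc3n2Cc2ccccc2F)CC1` is not yet measured. It differs from compound 2 by fluoro in place of methyl on an aromatic carbon. Within the data shown here, no measured step touches this part of the structure: the step from compound 1 to compound 3 concerns the group on the carbonyl carbon, and compound 1 and compound 2 differ in more than one place, so only their two values can be set side by side. With no guide in the data, a step as large as that from compound 1 to compound 3 is not expected here. Relative to compound 2, compound 4 is expected to move by only a number 0.9 percentage points higher from compound 2 to compound 4 (within the scatter), within the scatter. The estimate for compound 4 in this assay is 30%, with a range from 10% to 55%.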

Compound 4, a percentage reported as inhibition, at one concentration (the size of the read-out at that concentration, not a potency): 40.7%
For compound 4 the middle estimate is 10.7 percentage points below the measured one, and the stated range covers the measured number.
By their numbers in this assay, from the lowest: compounds 3 and 2 (each within the scatter of the next); then compound 4; then compound 1.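

Fluoro in place of methyl on an aromatic carbon, ortho to a large group, gives a number 11.6 percentage points higher from compound 2 to compound 4 (beyond the scatter) in this assay, the first measured step at this part of the structure. Within the data shown here, until now the only single-place step concerned the group on the carbonyl carbon, so the earlier compounds could not show that the 2-methylbenzyl group of compound 2 responds at all to the exchange of one heavy atom for another; this step is modest, whereas a number 62.2 percentage points lower from compound 1 to compound 3 (beyond the scatter) at the carbonyl carbon is large. Nothing at hand bears on what lies behind the step from methyl to fluoro.

On these data alone, the reading rests on a single pair of compounds, so it remains open how a chloro group, a methoxy group or a plain hydrogen at the same place would compare with methyl and fluoro. Also open, as far as these compounds go, is whether fluoro in place of methyl would move the number in the same direction on the benzyl ring of compound 1, which differs from compound 4 in more than one place and so cannot be compared with it directly.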